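A few compounds are considered here, and "the series" means these few. Any claim that something is new, unique, unknown or untested is made for them only; others in the source may bear on it.

In an ADME assay on microsomes (Homo sapiens) for metabolic stability (a lower number here means slower removal, a higher number faster removal of the compound), compound 1 `CNC(=O)[C@@H]1CCCN1S(=O)(=O)c1ccc(Cl)c(COc2cccc3c(C(F)(F)F)cc(C)nc23)c1Cl` gives 250 mL/min/kg, compound 2 `CNC(=O)[C@@H]1CCCN1S(=O)(=O)c1ccc(Cl)c(COc2cccc3c(-c4ccccn4)cc(C)nc23)c1Cl` gives 183 mL/min/kg and compound 3 `CNC(=O)[C@@H]1CCCN1S(=O)(=O)c1ccc(Cl)c(COc2cccc3c(-c4cccnc4)cc(C)nc23)c1Cl` gives 233 mL/min/kg. Compound 3 therefore sits level with the other two, as all three numbers lie within the scatter of one another. Compound 4 `CNC(=O)[C@@H]1CCCN1S(=O)(=O)c1ccc(Cl)c(COc2cccc3c(-c4ccncc4)cc(C)nc23)c1Cl` differs from compound 3 by pyridin-4-yl in place of pyridin-3-yl on an aromatic carbon. The nearest measured change, pyridin-3-yl in place of pyridin-2-yl, gave a 1.3-fold higher number from compound 2 to compound 3 (0.10 log units; within the scatter). Replacing trifluoromethyl gave a 1.4-fold lower number from compound 1 to compound 2 (0.14 log units; within the scatter) and a 1.1-fold lower number from compound 1 to compound 3 (0.03 log units; within the scatter). No step beyond the scatter is expected in this assay, in either direction. The expected step is a 1.1-fold lower number from compound 3 to compound 4 (0.03 log units; within the scatter). The estimate for compound 4 is 215 mL/min/kg, with an expected range of 135 mL/min/kg to 310 mL/min/kg.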

Compound 4, clearance: 217 mL/min/kg
Estimate against measurement, compound 4: 1.0-fold (0.00 log units) below; the range from low to high includes it.
By their numbers in this assay, from the lowest: compounds 2, 4, 3 and 1 (each within the scatter of the next).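

At the aromatic carbon opposite the ring nitrogen, pyridin-4-yl separates from neither of the other pyridines in this assay, with a 1.1-fold lower number from compound 3 to compound 4 (0.03 log units; within the scatter) and a 1.2-fold higher number from compound 2 to compound 4 (0.07 log units; within the scatter). It also stays level with trifluoromethyl, with a 1.2-fold lower number from compound 1 to compound 4 (0.06 log units; within the scatter), so moving the pyridine attachment point among these three gives no step beyond the scatter. No measured evidence on hand bears on this result. Open, from the compounds shown here alone, is whether a morpholine or a carboxylic acid at this carbon would shift the number beyond the scatter, and whether a change elsewhere on the shared core would.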